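The compounds below may be only part of what the source reports. "The series", "measured", "known", "first", "only" and "open" are said of these compounds alone.

Of the compounds shown here, two have been tested in an assay on isolated protein for inhibition of Nicotinamide phosphoribosyltransferase (Homo sapiens), read by mass spectrometry, with stated times of 15 min and 30 min; on this read-out higher numbers stand for weaker inhibition and lower numbers for stronger inhibition. Compound 1, `O=C(NCc1ccc(S(=O)(=O)c2ccccc2)cc1)N1CCc2ccncc2C1`, gives 310 nM in this assay. Compound 2, `O=C(NCc1ccc(S(=O)(=O)c2cc(F)cc(F)c2)cc1)N1Cc2ccncc2C1`, gives 7.1 nM in this assay. Of the two numbers, compound 2 has the lower one, and its distance from compound 1 lies well beyond the usual scatter of such measurements. Compound 3, `O=C(NCc1ccc(S(=O)(=O)C2CCN(C3COC3)CC2)cc1)N1Cc2ccncc2C1`, has not yet been measured. It differs from compound 2 in one place: 1-(oxetan-3-yl)piperidin-4-yl in place of 3,5-difluorophenyl on a sulfonyl sulfur. Going by the values given here, no measured pair shows a change of this kind, so there is no step to read it against. A saturated, heteroatom-rich group now takes the place of an aromatic ring, and a moderate loss relative to compound 2 is expected rather than a gain, with the step from compound 2 to compound 3 estimated at a 7.0-fold higher number from compound 2 to compound 3 (0.85 log units; beyond the scatter). For compound 3 the expected value in this assay is 50 nM, within a range from 10 nM to 400 nM.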

Compound 3, half-maximal inhibitory concentration: 31 nM
Estimate against measurement, compound 3: 1.6-fold (0.21 log units) above, and the stated range covers the measured number.
By their numbers in this assay, from the lowest: compound 2; then compound 3; then compound 1.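

On a sulfonyl sulfur, an aromatic ring is not needed for strong inhibition in this assay: 1-(oxetan-3-yl)piperidin-4-yl replaces 3,5-difluorophenyl with a 4.4-fold higher number from compound 2 to compound 3 (0.64 log units; beyond the scatter) as a modest loss, and compound 3 still gives 31 nM in the same assay. This place therefore accepts a group with two non-aromatic rings, one holding nitrogen and one holding oxygen, as well as a fluorinated aromatic ring. No measurement here explains why the number rises.

It remains open which part of the entering group matters, since only the complete 1-(oxetan-3-yl)piperidin-4-yl group is shown. A plain piperidin-4-yl or a cyclohexyl group on the same sulfonyl sulfur would help separate the contribution of the oxetane ring from that of the six-membered ring.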